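The source may hold more compounds than are shown below. What is called first, only, known or untested is meant among the compounds shown, and "the series" means these compounds.

Compounds measured so far:

- compound 1, `O=C1NCCN1C(c1ccccc1)(c1ccccc1)c1ccccc1`: 21000 nM
- compound 2, `COc1cc(NC(C)CCCNC(=O)Nc2ccc(Cl)c(C(F)(F)F)c2)c2ncccc2c1`: 3400 nM
- compound 3, `COc1cc(NC(C)CCCNC(=O)NNC(=O)N(C)C(c2ccccc2)c2ccccc2)c2ncccc2c1`: 19000 nM

These three were tested in a functional assay on MOLT-4 cells (Homo sapiens) for inhibition, read by MTT assay, with a stated time of 4 days; on this read-out lower numbers stand for stronger inhibition and higher numbers for weaker inhibition. Compound 2 gives the lowest number of the three, and its gaps to compound 3 and to compound 1 both lie beyond the usual scatter, so on these numbers compound 2 is the most potent of the three.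

Compound 4, `COc1cc(NC(C)CCCNC(=O)NNC(=O)NCCCO)c2ncccc2c1`, has not yet been measured. It differs from compound 2 in one place: ((3-hydroxypropyl)carbamoyl)amino in place of 4-chloro-3-(trifluoromethyl)phenyl on an amide-type nitrogen. Among the compounds with values here, no pair of measured compounds shares exactly this change, so the step cannot be read off directly. What the numbers do show is that compound 3, which also carries a carbamoylamino extension on the urea instead of an aryl ring, sits well above compound 2. On that basis the step from compound 2 to compound 4 in this assay is expected to go toward a higher number, beyond the scatter. For compound 4 the expected value is 30000 nM, with a range from 10000 nM to 90000 nM, meaning an expected step of an 8.8-fold higher number from compound 2 to compound 4 (0.95 log units; beyond the scatter).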

Compound 4, half-maximal inhibitory concentration: > 250000 nM
Compound 4 was reported as a limit (the forecaster's own chance of this, stated with the estimate: 25%); middle value at least 8.3-fold (0.92 log units) from the limit.
By their numbers in this assay, from the lowest: compound 2; then compounds 3 and 1 (each within the scatter of the next). At a limit, above all of these: compound 4.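

In this assay, the amide-type nitrogen whose other neighbour is the carbonyl carbon proves sensitive to what it carries: putting ((3-hydroxypropyl)carbamoyl)amino in place of 4-chloro-3-(trifluoromethyl)phenyl gives an at least 73-fold higher number from compound 2 to compound 4 (1.86 log units; beyond the scatter). This is the only step among the compounds shown that changes one place, so the effect of a change at this position can now be read directly. Compound 4 is reported only as a limit, so the full size of the step stays unknown: the limit of > 250000 nM in this assay, at which 1 of the 4 values shown sits.

The change removes the aromatic ring and brings in an open chain in a single step, so these compounds cannot separate the loss of the one from the gain of the other. As far as these compounds go, how a longer chain, or an amine in place of the hydroxy group, would behave on this nitrogen remains open.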